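The compounds below may be only part of what the source reports. "The series", "measured", "known", "first", "only" and "open" are said of these compounds alone.

Two compounds built on the same core have been compared in a functional assay on COLO 205 cells (Homo sapiens) for cytotoxicity, read by sulforhodamine B assay, with a stated time of 48 h, tested at 10 uM; on this read-out lower numbers stand for a stronger effect and higher numbers for a weaker effect at the one concentration tested. Compound 1, `COc1ccc(-c2cc(/C=C/C(=O)c3ccc(N)cc3)[nH]n2)cc1`, gives -86% in this assay. Compound 2, `COc1cc(-c2cc(/C=C/C(=O)c3ccc(N)cc3)[nH]n2)cc(OC)c1OC`, gives -84% in this assay. Of the two numbers shown, the one for compound 2 reads higher, but the gap to compound 1 lies within the usual scatter of repeated measurements, so the two compounds cannot be told apart on this read-out; neither counts as stronger or weaker. Compound 3, `COc1ccc(-c2cc(/C=C/C(=O)c3ccc(N)cc3)[nH]n2)cc1OC`, has not yet been measured. It differs from compound 2 in one place: hydrogen in place of methoxy on an aromatic carbon. Within the data shown here, no step between two measured compounds follows this kind of change, so nothing measured says directly how large its effect should be. Because compound 1 gives -86% and compound 2 gives -84% while carrying different numbers of methoxy groups, a step of no size beyond the scatter is expected here. The estimated step is a number 1 percentage points lower from compound 2 to compound 3 (within the scatter) in this assay. Compound 3 is therefore expected to give about -85%, within a range from -95% to -70%.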

Compound 3, a percentage reported as activity, at one concentration (the size of the read-out at that concentration, not a potency): -79%
The estimate for compound 3 lay 6 percentage points below the measured number; the range from low to high includes it.
By their numbers in this assay, from the lowest: compounds 1, 2 and 3 (each within the scatter of the next).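

Among these compounds, these are the first direct one-place steps at this ring carbon, which is ortho to a methoxy group and meta to a large group. In this assay, replacing that methoxy with hydrogen gives a number 5 percentage points higher from compound 2 to compound 3 (within the scatter), while the matching swap in the other direction, methoxy in place of hydrogen on the core of compound 1, gives a number 7 percentage points higher from compound 1 to compound 3 (within the scatter), so neither step separates hydrogen from methoxy at this kind of carbon, and the read-out tolerates both. Nothing available explains this tolerance.

The compounds shown leave open whether a different group on this carbon, such as a hydroxyl, an amine, a carboxylic acid or a longer ether chain, would produce a step beyond the scatter. They also leave open whether the ring would keep this read-out with no methoxy group at all, and whether these compounds would still be indistinguishable at a lower concentration, where a single reading might separate them better.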